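This account rests on a few compounds, and the source may have more. Where it says the series, first, only, none or still open, it means among the compounds named here.

Working notes on the series. Compound 1 (`CC(C)(C)NCc1c(C(=O)O)nn(-c2ccc(Cl)cc2)c1-c1ccc(F)cc1`), compound 2 (`CC(C)(C)NCc1c(C(=O)O)nn(-c2ccc(Cl)cc2)c1-c1ccc(Cl)cc1`) and compound 3 (`CC(C)(C)NCc1c(C(=O)O)nn(-c2ccc(Cl)cc2)c1-c1ccccc1`) share one core and differ at a single place on one aromatic ring, which carries fluoro, chloro or hydrogen. In an ADME assay on HaCaT cells (Homo sapiens) for inhibition, read by sulforhodamine B assay, with a stated time of 48 h (on this read-out higher numbers stand for weaker inhibition of growth and lower numbers for stronger inhibition of growth), compound 1 gives 28700 nM, compound 2 gives 87500 nM and compound 3 gives 175000 nM. Compound 3 has one close neighbour and one distant one: a 2.0-fold higher number from compound 2 to compound 3 (0.30 log units; within the scatter), whereas a 6.1-fold higher number from compound 1 to compound 3 (0.79 log units; beyond the scatter). The two halogens are also separated, with a 3.0-fold higher number from compound 1 to compound 2 (0.48 log units; beyond the scatter).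

Compound 4 (`CC(C)(C)NCc1c(C(=O)O)nn(-c2ccc(Cl)cc2)c1-c1ccc([N+](=O)[O-])cc1`) departs from compound 3 on an aromatic carbon of a six-membered aromatic ring of carbon only, para to a large group: nitro in place of hydrogen on an aromatic carbon. This is phenyl to 4-nitrophenyl, at the place varied so far. Among the measured compounds shown here, no nitro compound has been measured, so the two steps ending in hydrogen are the only guide. Read backwards, the fluoro step points to a lower number once hydrogen is replaced, while the chloro step stays within the scatter and so gives compound 2 no support for that reading. A modest step towards a lower number is therefore expected in this assay, with real uncertainty about its size. The expected change is a 2.5-fold lower number from compound 3 to compound 4 (0.40 log units; beyond the scatter). For compound 4 the estimate is 70000 nM, with an expected range of 25000 nM to 170000 nM.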

Compound 4, concentration for 50% growth inhibition: > 583000 nM
Compound 4 ended at the assay's limit (the forecaster's own chance of this, stated with the estimate: 5%); at least 8.3-fold (0.92 log units) between middle value and limit.
By their numbers in this assay, from the lowest: compound 1; then compounds 2 and 3 (each within the scatter of the next). At a limit, above all of these: compound 4.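

In this assay compound 4 gives > 583000 nM, which is a limit of the assay and not a number: the limit of > 583000 nM in this assay, at which 1 of the 4 values shown sits. Substitution at this place on the aromatic ring does not act in one direction: the fluoro compound stands lower than the unsubstituted one, with a 6.1-fold higher number from compound 1 to compound 3 (0.79 log units; beyond the scatter), whereas nitro in place of hydrogen goes the other way, with an at least 3.3-fold higher number from compound 3 to compound 4 (0.52 log units; beyond the scatter). The range at this place is also wider than the halogens and hydrogen alone suggested, with an at least 6.6-fold higher number from compound 2 to compound 4 (0.82 log units; beyond the scatter) and an at least 20-fold higher number from compound 1 to compound 4 (1.30 log units; beyond the scatter). Compound 4 sits at a limit. These sizes are only minimum sizes.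

The compounds shown leave open where an amino, methoxy or methyl group at this place would fall relative to fluoro and nitro, and so whether any single trend links the groups at this position. They also leave open whether the same nitro change would have a comparable effect if the carboxylic acid of the shared core were replaced by an ester or an amide.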